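A few compounds are considered here, and "the series" means these few. Any claim that something is new, unique, unknown or untested is made for them only; others in the source may bear on it.

Of the compounds shown here, three of one shared core have been tested in a functional assay on HeLa cells (Homo sapiens) for inhibition, read by sulforhodamine B assay, with a stated time of 48 h; on this read-out higher numbers stand for weaker inhibition of growth and lower numbers for stronger inhibition of growth. Compound 1 `COC(=O)[C@@]1(C)CCC=C2[C@@H]1CC[C@@H](C)[C@]2(C)Cc1c[nH]c2ccc(F)cc12` gives 3700 nM in this assay. Among the measured compounds shown here, compound 2 `COC(=O)[C@@]1(C)CCC=C2[C@@H]1CC[C@@H](C)[C@]2(C)Cc1c(C)[nH]c2ccccc12` gives 11000 nM, and compound 3 `COC(=O)[C@@]1(C)CCC=C2[C@@H]1CC[C@@H](C)[C@]2(C)Cc1c(C)[nH]c2ccc(Cl)cc12` gives 12000 nM, the highest number of the three; the only single step among them, a 1.1-fold higher number from compound 2 to compound 3 (0.04 log units; within the scatter), changes little. Against compound 1 the number of compound 3 is higher by a margin beyond the scatter, but the two differ in more than one place, so only the two values themselves speak.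

Compound 4 `COC(=O)[C@@]1(C)CCC=C2[C@@H]1CC[C@@H](C)[C@]2(C)Cc1c(C)[nH]c2ccc(F)cc12` differs from compound 3 by fluoro in place of chloro on an aromatic carbon. For the measured compounds named here, no measured pair shows fluoro in place of chloro on this ring; the nearest guide is the step from compound 2 to compound 3, where adding chloro to compound 2 left the number within the scatter, so the halogen at this place looks weakly felt. A step of a 1.2-fold lower number from compound 3 to compound 4 (0.08 log units; within the scatter) is therefore expected, amounting to no change beyond the scatter. Compound 4 is estimated at 10000 nM, with a range from 4000 nM to 25000 nM.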

Compound 4, concentration for 50% growth inhibition: 11000 nM
The estimate for compound 4 lay 1.1-fold (0.04 log units) below the measured number, and the stated range covers the measured number.
By their numbers in this assay, from the lowest: compound 1; then compounds 2, 4 and 3 (each within the scatter of the next).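

In this assay the step of a 1.1-fold lower number from compound 3 to compound 4 (0.04 log units; within the scatter) exchanges one halogen for the other, and the step of no change at the digits printed from compound 2 to compound 4 (within the scatter) sets fluoro in place of hydrogen; both lie within the scatter, so hydrogen, fluoro and chloro on this aromatic carbon are not told apart here. The step of a 3.0-fold higher number from compound 1 to compound 4 (0.47 log units; beyond the scatter) is the first single change shown to lie beyond the scatter, though it is modest, and it places the effect on the methyl in place of hydrogen rather than on the halogen. Nothing available explains either result.

Going by these compounds, it remains open whether an amine or a carboxylic acid on the halogen-bearing carbon would move the number beyond the scatter. On these data alone, it is also open whether an ethyl group in place of the methyl would extend or reverse the step seen with methyl.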